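Bromo Substitution Against an Upper Assay Limit

The source may report more compounds than this note shows. Statements on the series, on what has been measured and on what is new or still open speak of the compounds shown alone.

Compound 1 `Nc1cccn2cc(Cc3ccccc3)c(=O)nc12` was measured in a functional assay on HepG2 cells (Homo sapiens) for cytotoxicity, read by MTT assay, with a stated time of 24 h (on this read-out lower numbers stand for stronger inhibition and higher numbers for weaker inhibition), and gave 131000 nM. Compound 2 `O=c1nc2ccccn2cc1Cc1ccccc1` reached only the assay limit, > 1000000 nM. Compound 3 `Nc1cc(Br)cn2cc(Cc3ccccc3)c(=O)nc12` likewise stopped at the limit, > 1000000 nM. Removing the amino group gave an at least 7.6-fold higher number from compound 1 to compound 2 (0.88 log units; beyond the scatter), and adding bromo gave an at least 7.6-fold higher number from compound 1 to compound 3 (0.88 log units; beyond the scatter); both ran into (the limit of > 1000000 nM in this assay, at which 2 of the 3 values shown sit).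

Compound 4 `O=c1nc2ccccn2cc1Cc1ccc(Br)cc1` is not yet measured. It differs from compound 2 by bromo in place of hydrogen on an aromatic carbon, the same kind of change as bromo in place of hydrogen on an aromatic carbon, though there the bromo sat on a six-membered aromatic ring with 1 nitrogen, meta to an amino group, while here it sits on a six-membered aromatic ring of carbon only, para to a large group. The two cores differ by hydrogen in place of amino on an aromatic carbon.

Compound 4 is expected to remain at the limit, an estimated 1500000 nM. This expectation rests on compound 2 already sitting at the limit > 1000000 nM. It also rests on the earlier bromo step, an at least 7.6-fold higher number from compound 1 to compound 3 (0.88 log units; beyond the scatter). The estimated step is thus a step that the limit leaves unreadable from compound 2 to compound 4.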

Compound 4, half-maximal inhibitory concentration: > 1000000 nM
Compound 4 ended at the assay's limit; the forecaster's own chance of this, stated with the estimate: 80%; the middle value does not contradict the limit.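

No step can be read from compound 2 to compound 4, since both values are limits of the assay: the limit of > 1000000 nM in this assay, at which 3 of the 4 values shown sit.

As far as these compounds go, whether bromo on the six-membered aromatic ring of carbon only changes the cytotoxicity of this core at all remains open.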